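Nitro Group Added to a Compound at the Assay Limit

This account rests on a few compounds, and the source may have more. Where it says the series, first, only, none or still open, it means among the compounds named here.

Measured compounds:
compound 1, `COc1ccc(-c2c(-c3cc(OC)c(OC)c(OC)c3)ssc2=S)cc1` — 2270 nM
compound 2, `COc1ccc(-c2c(-c3cc(OC)c(OC)c(OC)c3)ssc2=S)cc1[N+](=O)[O-]` — 3550 nM
compound 3, `COc1ccc(-c2c(-c3cc(OC)c(OC)c(OC)c3)ss/c2=N/O)cc1` — > 100000 nM (a limit of the assay, not a number)

In a functional assay on HT-1080 cells (Homo sapiens) for antiproliferative activity, read by MTT assay, with a stated time of 72 h (on this read-out higher numbers stand for weaker inhibition and lower numbers for stronger inhibition), compound 1 gives 2270 nM. Compound 2 differs from compound 1 by nitro in place of hydrogen on an aromatic carbon, and in this assay compound 2 gives 3550 nM, a step of a 1.6-fold higher number from compound 1 to compound 2 (0.19 log units; within the scatter). Compound 3 has a different core from compound 1; the difference between the two cores is not broken down here. In this assay compound 3 reaches only the limit of the assay, > 100000 nM. Compound 4, `COc1ccc(-c2c(-c3cc(OC)c(OC)c(OC)c3)ss/c2=N/O)cc1[N+](=O)[O-]`, is made from compound 3 by nitro in place of hydrogen on an aromatic carbon, the same change that leads from compound 1 to compound 2, at a place described in the same words. The step from compound 3 to compound 4 in this assay is expected to be a number no higher from compound 3 to compound 4 (the limit leaves the size open), which rests on the step of a 1.6-fold higher number from compound 1 to compound 2 (0.19 log units; within the scatter) lying within the scatter and on compound 3 sitting at the limit of > 100000 nM in this assay, at which 1 of the 3 values shown sits. Compound 4 is therefore expected to give about 100000 nM in this assay, between 50000 nM and 200000 nM, most likely again reported only as a limit.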

Compound 4, half-maximal inhibitory concentration: 3030 nM
Beside the measured number, compound 4's estimate is 33-fold (1.52 log units) above it, outside the stated range (below it).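

In this assay, nitro in place of hydrogen on an aromatic carbon gives an at least 33-fold lower number from compound 3 to compound 4 (1.51 log units; beyond the scatter), so this change makes a large difference on the core of compound 3, whereas on the core of compound 1 it gives a 1.6-fold higher number from compound 1 to compound 2 (0.19 log units; within the scatter). As far as these compounds go, compound 3 stands at a limit of the assay, > 100000 nM, which is not a number, so the full size of its step remains unknown. The step on one core therefore did not carry over to the other, although a single pair of cores does not show why or how the change would behave on any further core: the same change on two cores in this assay, a 1.6-fold higher number (0.19 log units; within the scatter) from compound 1 to compound 2 and an at least 33-fold lower number (1.51 log units; beyond the scatter) from compound 3 to compound 4, at least 51-fold (1.71 log units) apart, beyond the scatter of two such steps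

The compounds shown leave open whether the lower number for compound 4 belongs to nitro alone or would also come with an amine or a nitrile at the same place. They also leave open whether a longer chain in place of the methoxy group ortho to that place would shift the values on either core.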